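Working notes: hydrogen for methyl on an aromatic nitrogen

The source may report more compounds than this note shows. Statements on the series, on what has been measured and on what is new or still open speak of the compounds shown alone.

Measured values in a functional assay on A549 cells (Homo sapiens) for inhibition, read by sulforhodamine B assay, with a stated time of 72 h (on this read-out higher numbers stand for weaker inhibition of growth and lower numbers for stronger inhibition of growth), follow
- compound 1 `CCOC(=O)/C=C/c1ccncc1-c1ccc2[nH]ccc2c1` gives 7440 nM
- compound 2 `CNC(=O)/C=C/c1ccncc1-c1ccc2c(ccn2C)c1` gives 6450 nM

Compound 2 stands level with compound 1 in this assay within the usual scatter, so the two numbers show no separation. Compound 3 `CNC(=O)/C=C/c1ccncc1-c1ccc2[nH]ccc2c1` differs from compound 2 by hydrogen in place of methyl on an aromatic nitrogen with hydrogen in place of methyl on an aromatic nitrogen. Going by the values given here, no measured pair isolates this change. Among the compounds with values here, with compound 1 at 7440 nM and compound 2 at 6450 nM as the only guide, no shift beyond the scatter is expected in either direction in this assay for this change. The expected move is a 1.0-fold higher number from compound 2 to compound 3 (0.00 log units; within the scatter) and is estimated to be small. In this assay the value expected for compound 3 is 6500 nM (range 2500 nM to 17000 nM).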

Compound 3, concentration for 50% growth inhibition: > 10000 nM
Compound 3 ended at the assay's limit; the forecaster's own chance of this, stated with the estimate: 8%; middle value at least 1.5-fold (0.18 log units) away from the limit.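

In this assay compound 3 gives > 10000 nM, which is a limit of the assay and not a number. Hydrogen in place of methyl on an aromatic nitrogen gives an at least 1.5-fold higher number from compound 2 to compound 3 (0.19 log units; that floor lies within the scatter), the first reading for this position, though only a floor. Methylamino in place of ethoxy on a carbonyl carbon gives an at least 1.3-fold higher number from compound 1 to compound 3 (0.12 log units; that floor lies within the scatter), so neither floor clears the scatter.

Going by these compounds, how far either step runs past its floor stays open. So does the effect of ethyl on that aromatic nitrogen, or of dimethylamino on the carbonyl carbon.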